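The compounds below may be only part of what the source reports. "The series", "measured", "known", "first", "only" and "open" are said of these compounds alone.

Measured in an assay on HEK293 cells for inhibition of N-acylethanolamine-hydrolyzing acid amidase (Rattus norvegicus), read by LC-MS, with a stated time of 30 min; a higher number here means a weaker inhibitor, a lower number a stronger inhibitor: Compound 1 `Cc1ccccc1-c1ccc(CCC(=O)N2CCCC2)cc1` sits at the limit of the assay, > 100000 nM. Compound 2 `O=C(CCCCCCc1cccs1)N1CCCC1` gives 14100 nM. Compound 3 `O=C(CCCCCCC1CCCCC1)N1CCCC1` gives 5700 nM.

Compound 1 is the one of the three for which only a limit and no number is known (the limit of > 100000 nM in this assay, at which 1 of the 3 values shown sits). Compound 4 `O=C(CCc1ccc(C2CCCCC2)cc1)N1CCCC1` differs from it by cyclohexyl in place of 2-methylphenyl on an aromatic carbon. For the measured compounds named here, the only measured step that bears on this is a 2.5-fold lower number from compound 2 to compound 3 (0.39 log units; beyond the scatter), where a cyclohexyl replaced thiophen-2-yl on a saturated chain carbon. In the present case the exchange sits on an aromatic carbon and the leaving group is 2-methylphenyl, so the carry-over is loose. A step in the same direction is expected, an at least 2.5-fold lower number from compound 1 to compound 4 (0.39 log units; beyond the scatter), although a second result at the limit cannot be excluded. Compound 4 is estimated at 40000 nM, with a range of 8000 nM to 200000 nM.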

Compound 4, half-maximal inhibitory concentration: 500 nM
Compound 4: the middle estimate sits 80-fold (1.90 log units) above what was measured; the whole stated range lies above it.
By their numbers in this assay, from the lowest: compound 4; then compound 3; then compound 2. At a limit, above all of these: compound 1.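

In this assay, cyclohexyl in place of 2-methylphenyl on an aromatic carbon, para to a group of 9 heavy atoms, turns an inactive-looking compound into the most potent of the four: an at least 200-fold lower number from compound 1 to compound 4 (2.30 log units; beyond the scatter). This step is much larger than the only earlier one involving cyclohexyl, a 2.5-fold lower number from compound 2 to compound 3 (0.39 log units; beyond the scatter), which lay on a saturated chain carbon. Its full size stays unknown, as compound 1 has only a limit: the limit of > 100000 nM in this assay, at which 1 of the 4 values shown sits.

Open, on these data alone, is whether plain phenyl or cyclopentyl at this position would match compound 4. Also open, as far as these compounds go, is how a longer chain to the carbonyl would read.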